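Pyridin-2-yl replacing 2-chlorophenyl on the ring amine nitrogen

The compounds below may be only part of what the source reports. "The series", "measured", "known", "first", "only" and "open" are said of these compounds alone.

Measured compounds:
compound 1 `Nc1nc(N)c2cc(CSC(=S)N3CCN(c4ccccc4)CC3)ccc2n1`: 2970 nM
compound 2 `Nc1nc(N)c2cc(CSC(=S)N3CCN(c4ccccc4Cl)CC3)ccc2n1`: 3610 nM

Among the compounds with values here, in a functional assay on A549 cells (Homo sapiens) for antiproliferative activity, read by MTT assay, with a stated time of 72 h (on this read-out lower numbers stand for stronger inhibition and higher numbers for weaker inhibition), compound 2 gives 3610 nM and carries the highest of the two numbers so far; its nearest neighbour is compound 1, and the step of a 1.2-fold higher number from compound 1 to compound 2 (0.08 log units; within the scatter) lies within the scatter, so the two cannot be ordered.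

Compound 3 `Nc1nc(N)c2cc(CSC(=S)N3CCN(c4ccccn4)CC3)ccc2n1` is not yet measured. It differs from compound 2 by pyridin-2-yl in place of 2-chlorophenyl on an amine nitrogen in a ring.

Within the data shown here, no measured step bears directly on this exchange: the only step available, chloro in place of hydrogen on the aromatic carbon from compound 1 to compound 2, was within the scatter, and no pair here compares a carbon-only aromatic ring with a ring holding one hetero atom. On that basis a step of no more than the scatter is expected, in no preferred direction, a 1.1-fold lower number from compound 2 to compound 3 (0.04 log units; within the scatter).

Compound 3 is therefore estimated at 3300 nM, with a range from 1500 nM to 7500 nM.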

Compound 3, half-maximal inhibitory concentration: 3960 nM
For compound 3 the middle estimate is 1.2-fold (0.08 log units) below the measured one, and the stated range covers the measured number.
By their numbers in this assay, from the lowest: compounds 1, 2 and 3 (each within the scatter of the next).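

Working from this assay, the group on the amine nitrogen in the ring now extends to an aromatic ring with a hetero atom, and the readings show a 1.1-fold higher number from compound 2 to compound 3 (0.04 log units; within the scatter) and a 1.3-fold higher number from compound 1 to compound 3 (0.12 log units; within the scatter). Pyridin-2-yl therefore cannot be told apart from either 2-chlorophenyl or phenyl at this position, and the hydrogen-bond acceptor counted on pyridin-2-yl brings no change that stands clear of the scatter in these three compounds. No measured evidence bears on why these numbers stay together.

Whether this position tolerates only aromatic six-membered rings remains open, since a non-aromatic group such as a cyclohexyl ring, a benzyl group or a short alkyl chain is not among the compounds shown. Also open, as far as these compounds go, is whether a carboxylic acid or an amine on the aromatic ring would move the number beyond the scatter.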